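A few compounds are considered here, and "the series" means these few. Any claim that something is new, unique, unknown or untested is made for them only; others in the source may bear on it.

Compound 1 `Cc1cc(NCc2ccccn2)n2ncc(Br)c2n1` gives 89300 nM in a physicochemical assay for solubility, read by HPLC, using the shake flask method, measured as kinetic solubility, with a stated time of 2 h, at pH 7.4 (a higher number here means a more soluble compound, a lower number a less soluble compound), the lowest of the two numbers shown, with compound 2 `Cc1cc(NCc2cccnc2)n2nc(C)c(-c3ccccc3)c2n1` nearest at 110000 nM, a gap within the scatter. Compound 3 `Cc1cc(NCc2ncc[nH]2)n2nc(C)c(-c3ccccc3)c2n1` reports only a limit, < 5000 nM, (the limit of < 5000 nM in this assay, at which 1 of the 3 values shown sits). Within the data shown here, the single measured step, an at least 22-fold lower number from compound 2 to compound 3 (1.34 log units; beyond the scatter), concerns the group on the saturated chain carbon and does not touch the position altered here. Compound 4 `Cc1cc(NCc2ccccn2)n2ncc(-c3cc(F)c(F)c(F)c3)c2n1` differs from compound 1 by 3,4,5-trifluorophenyl in place of bromo on an aromatic carbon. Among the measured compounds shown here, no measured step covers this change; compound 2 carries a phenyl at the corresponding place but also differs from compound 1 elsewhere, so its value yields no step. For compound 4 a modest drop in this assay is expected, a 2.2-fold lower number from compound 1 to compound 4 (0.35 log units; beyond the scatter). The estimate for compound 4 is 40000 nM, between 10000 nM and 120000 nM.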

Compound 4, solubility: < 5000 nM
Compound 4: no number, only a limit (the forecaster's own chance of this, stated with the estimate: 15%); middle value at least 8.0-fold (0.90 log units) away from the limit.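

At this aromatic carbon of the five-membered ring, 3,4,5-trifluorophenyl in place of bromo gives a large step in this assay: an at least 17-fold lower number from compound 1 to compound 4 (1.25 log units; beyond the scatter). Compound 4 reports only a limit, < 5000 nM, so the full size of the step cannot be read. Changes at two different places now end at the same limit: the limit of < 5000 nM in this assay, at which 2 of the 4 values shown sit.

As far as these compounds go, whether a phenyl ring carrying an amine or a carboxylic acid at this place would hold the number nearer compound 1 stays open. The ring and its three fluorines also remain unseparated, as compound 2 differs from compound 1 elsewhere too.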